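This account rests on a few compounds, and the source may have more. Where it says the series, first, only, none or still open, it means among the compounds named here.

Measured compounds:
Compound 1, `CCCCCCCCCCCC(=O)Nc1nnc(S[C@@H]2O[C@H](COC(C)=O)[C@H](OC(C)=O)[C@H](OC(C)=O)[C@H]2OC(C)=O)s1`, gives 26700 nM in a functional assay on MDA-MB-231 cells (Homo sapiens) for cytotoxicity, read by MTT assay, with a stated time of 24 h; a lower number here means a stronger inhibitor, a higher number a weaker inhibitor.
Compound 2, `CCCCCC(=O)Nc1nnc(S[C@@H]2O[C@H](COC(C)=O)[C@H](OC(C)=O)[C@H](OC(C)=O)[C@H]2OC(C)=O)s1`, gives 25400 nM in this assay.

Compound 1 stands with the highest of these two numbers, and its nearest neighbour is compound 2; the step of a 1.1-fold lower number from compound 1 to compound 2 (0.02 log units; within the scatter) lies within the scatter, so the two cannot be placed in any order. Compound 3, `CCCCCCCC/C=C\CCCCCCCCCCCC(=O)Nc1nnc(S[C@@H]2O[C@H](COC(C)=O)[C@H](OC(C)=O)[C@H](OC(C)=O)[C@H]2OC(C)=O)s1`, differs from compound 1 by dec-1-en-1-yl in place of hydrogen on a saturated chain carbon, ten or more bonds along the chain from a carbonyl carbon. Going by the values given here, the only measured step that bears on this chain is a 1.1-fold lower number from compound 1 to compound 2 (0.02 log units; within the scatter), in which removing a large part of the chain left the number essentially unchanged. Extending the chain in compound 3 is therefore expected to give no step beyond the scatter in this assay, as expressed by the expected step of a 1.0-fold higher number from compound 1 to compound 3 (0.00 log units; within the scatter). Compound 3 is accordingly estimated at 27000 nM in this assay, with a range from 12000 nM to 60000 nM.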

Compound 3, half-maximal inhibitory concentration: 25300 nM
The estimate for compound 3 lay 1.1-fold (0.03 log units) above the measured number; measured number inside the range.
By their numbers in this assay, from the lowest: compounds 3, 2 and 1 (each within the scatter of the next).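

In this assay, the chain now has a change in the direction opposite to the earlier shortening: with dec-1-en-1-yl in place of hydrogen on a saturated chain carbon, the result is a 1.1-fold lower number from compound 1 to compound 3 (0.02 log units; within the scatter). This change adds a double bond outside aromatic rings as well as length, and neither alters the number beyond the scatter, so among these compounds both removing and adding chain carbons at this part of the molecule leave the reading unresolved. No available evidence accounts for this flat response.

The compounds shown leave open whether an amine or a carboxylic acid on this chain would move the number beyond the scatter. They also leave open whether a change outside the chain, such as a hydroxyl in place of an acetyl ester on the shared core, would do so.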